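Replacing Bromophenyl with Dimethylphenyl on the Hydrazone Carbon

The source may report more compounds than this note shows. Statements on the series, on what has been measured and on what is new or still open speak of the compounds shown alone.

Of the compounds shown here, three of a shared core have been tested in a functional assay on HeLa cells (Homo sapiens) for inhibition, read by CCK-8 assay, with a stated time of 48 h; a lower number here means a stronger inhibitor, a higher number a weaker inhibitor. Compound 1 `c1ccc(C2=NN(C3=NC(c4ccccc4)CS3)C(c3ccc4ccccc4c3)C2)cc1` gives 3860 nM. Compound 2 `Cc1ccc(C2=NN(C3=NC(c4ccccc4)CS3)C(c3cccc4ccccc34)C2)cc1C` gives 1720 nM. Going by the values given here, compound 3 `Brc1ccc(C2=NN(C3=NC(c4ccccc4)CS3)C(c3ccc4ccccc4c3)C2)cc1` gives 4960 nM, the highest of the three numbers; it sits close to compound 1, and the one measured step, a 1.3-fold higher number from compound 1 to compound 3 (0.11 log units; within the scatter), shows that adding bromo changed little.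

Compound 4 `Cc1ccc(C2=NN(C3=NC(c4ccccc4)CS3)C(c3ccc4ccccc4c3)C2)cc1C` is the next step from compound 3: 3,4-dimethylphenyl in place of 4-bromophenyl on a carbon with a double bond to nitrogen. Among the compounds with values here, no measured step covers this exchange directly. Within the data shown here, the only bearing comes from compound 2, which carries the same 3,4-dimethylphenyl group, though on a core that also differs in the naphthyl attachment, so its value is read only as a hint, not as a step. Taking compound 3 as the starting point and the value of compound 2 as the hint, compound 4 is expected to move to a lower number, with the step of a 2.0-fold lower number from compound 3 to compound 4 (0.30 log units; within the scatter) of moderate size. The estimate for compound 4 in this assay is 2500 nM, with a range from 1000 nM to 6000 nM, because compound 2 gives 1720 nM and compound 3 gives 4960 nM.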

Compound 4, half-maximal inhibitory concentration: 950 nM
The estimate for compound 4 lay 2.6-fold (0.42 log units) above the measured number; the measured number lies below the stated range.
By their numbers in this assay, from the lowest: compounds 4 and 2 (each within the scatter of the next); then compounds 1 and 3 (each within the scatter of the next).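

In this assay, the carbon with a double bond to nitrogen proves responsive to the group it carries: both the exchange of 4-bromophenyl for 3,4-dimethylphenyl (a 5.2-fold lower number from compound 3 to compound 4 (0.72 log units; beyond the scatter)) and that of phenyl for 3,4-dimethylphenyl (a 4.1-fold lower number from compound 1 to compound 4 (0.61 log units; beyond the scatter)) lie beyond the scatter, whereas the earlier bromo step (a 1.3-fold higher number from compound 1 to compound 3 (0.11 log units; within the scatter)) did not. With 3,4-dimethylphenyl in place, the naphthyl attachment on the saturated ring carbon makes no readable difference (a 1.8-fold lower number from compound 2 to compound 4 (0.26 log units; within the scatter)), so naphthalen-2-yl and naphthalen-1-yl cannot be told apart in this setting. No evidence is available to explain why the dimethylphenyl group behaves differently from the phenyl and 4-bromophenyl groups.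

The compounds shown leave open whether both methyl groups are needed, or whether a single methyl at either of the two ring places would give the same number. They also leave open how this position would respond to a methoxy group, an amine or a carboxylic acid on the phenyl ring, and whether the 3,4-dimethylphenyl effect holds in cell lines other than HeLa.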